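The source may hold more compounds than are shown below. What is called first, only, known or untested is meant among the compounds shown, and "the series" means these compounds.

Three compounds share one core and differ only in the group on one aromatic carbon. Compound 1 `CC(C(=O)NCc1ccc(C(F)(F)F)cc1N1CCCCCC1)c1ccc(NS(C)(=O)=O)c(F)c1` carries azepan-1-yl there; in an assay on CHO cells for antagonist activity at transient receptor potential cation channel subfamily V member 1 (Homo sapiens), read by FLIPR (on this read-out higher numbers stand for weaker inhibition and lower numbers for stronger inhibition), compound 1 gives 1.6 nM. Compound 2 `CC(C(=O)NCc1ccc(C(F)(F)F)cc1OCc1ccccc1)c1ccc(NS(C)(=O)=O)c(F)c1` carries benzyloxy instead, and in this assay compound 2 gives 0.9 nM. Compound 3 `CC(C)CCSc1cc(C(F)(F)F)ccc1CNC(=O)C(C)c1ccc(NS(C)(=O)=O)c(F)c1` carries isopentylsulfanyl, and in this assay compound 3 gives 1.4 nM. The three numbers sit close together: the step of a 1.8-fold lower number from compound 1 to compound 2 (0.25 log units; within the scatter), the step of a 1.1-fold lower number from compound 1 to compound 3 (0.06 log units; within the scatter) and the step of a 1.6-fold higher number from compound 2 to compound 3 (0.19 log units; within the scatter) all lie within the usual scatter, so none of the three can be called stronger or weaker than another, and compound 3 stands among them with nothing to separate it from compound 1 or compound 2.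

Compound 4 `CC(C(=O)NCc1ccc(C(F)(F)F)cc1SC1CCCC1)c1ccc(NS(C)(=O)=O)c(F)c1` is not yet measured. It differs from compound 3 in one place: cyclopentyl in place of isopentyl on a sulfur. The sulfur on the aromatic carbon stays; only the chain on it is exchanged for a ring. Among the measured compounds shown here, the steps that bear on this are a 1.1-fold lower number from compound 1 to compound 3 (0.06 log units; within the scatter) and a 1.6-fold higher number from compound 2 to compound 3 (0.19 log units; within the scatter), both small, showing that even exchanging the whole group on this carbon for a quite different one hardly moved the number. Exchanging only the outer part of the same group is therefore expected to move it little, and the step of a 1.1-fold higher number from compound 3 to compound 4 (0.03 log units; within the scatter) is expected to stay within the scatter. The estimate for compound 4 in this assay is 1.5 nM, with a range from 0.6 nM to 4 nM.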

Compound 4, inhibition constant: 0.3 nM
Compound 4: middle estimate off by 5.0-fold (0.70 log units), on the high side, and the stated range ends above it.
By their numbers in this assay, from the lowest: compound 4; then compounds 2, 3 and 1 (each within the scatter of the next).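

The earlier compounds shown here made this aromatic carbon look tolerant of almost any large group, but the step of a 4.7-fold lower number from compound 3 to compound 4 (0.67 log units; beyond the scatter) shows that the number can still respond to a small change there. The sulfur stays and the carbon count on it stays the same, yet replacing the open isopentyl chain with the cyclopentyl ring moves the number beyond the scatter in this assay. The steps of a 3.0-fold lower number from compound 2 to compound 4 (0.48 log units; beyond the scatter) and a 5.3-fold lower number from compound 1 to compound 4 (0.73 log units; beyond the scatter) are also beyond the scatter, making compound 4 the strongest of the four, so the close agreement among compounds 1, 2 and 3 does not extend to every group at this position, and nothing available here explains the difference between ring and chain.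

The compounds shown leave open whether other rings on the sulfur, such as cyclobutyl or cyclohexyl, or a short branched chain such as isopropyl, would give a similar number. They also leave open whether the sulfur itself matters, a question that a cyclopentyloxy group, with oxygen in place of sulfur, could answer directly.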